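From 3-chlorophenyl to 4-chlorophenyl: a small structural change

The compounds below may be only part of what the source reports. "The series", "measured", "known", "first", "only" and "open" are said of these compounds alone.

Within the data shown here, in a functional assay on UACC-62 cells (Homo sapiens) for cytotoxicity, read by sulforhodamine B assay (a lower number here means that less compound is tolerated, a higher number that more compound is tolerated), compound 2 (`CC1=CC[C@@H]([C@@](C)(O)CCCC(C)(C)NC(=S)N/N=C\c2cccc(Cl)c2)CC1`) gives 42700 nM and compound 1 (`CC1=CC[C@@H]([C@@](C)(O)CCCC(C)(C)NC(=S)N/N=C\c2ccccc2[N+](=O)[O-])CC1`) gives 49300 nM on the same read-out, so the only two numbers available lie within the scatter of each other. Compound 3 (`CC1=CC[C@@H]([C@@](C)(O)CCCC(C)(C)NC(=S)N/N=C\c2ccc(Cl)cc2)CC1`) has not yet been measured. It carries 4-chlorophenyl in place of 3-chlorophenyl on a carbon with a double bond to nitrogen, and the two compounds have the same atoms, joined differently. Among the measured compounds shown here, no measured pair yet isolates a change of this kind. For the measured compounds named here, the one measured step that bears on it is the replacement at the same place, a 1.2-fold lower number from compound 1 to compound 2 (0.06 log units; within the scatter) in the same assay, where 3-chlorophenyl took the place of 2-nitrophenyl. That larger exchange of groups left the number within the scatter, so the smaller change to compound 3 is not expected to do more. An estimated 1.0-fold higher number from compound 2 to compound 3 (0.00 log units; within the scatter) in this assay is therefore expected, with no shift beyond the scatter in either direction. Compound 3 is estimated at 43000 nM (expected range 25000 nM to 72000 nM).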

Compound 3, concentration lethal to 50% of the cells: 40600 nM
Compound 3: middle estimate off by 1.1-fold (0.02 log units), on the high side, and the stated range covers the measured number.
By their numbers in this assay, from the lowest: compounds 3, 2 and 1 (each within the scatter of the next).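

In this assay, among these compounds, 4-chlorophenyl in place of 3-chlorophenyl gives a 1.1-fold lower number from compound 2 to compound 3 (0.02 log units; within the scatter) and is the first measured pair in which the same atoms are joined differently at this place, so the two chlorophenyl groups cannot be told apart on this read-out. Against 2-nitrophenyl at the same place, 4-chlorophenyl gives a 1.2-fold lower number from compound 1 to compound 3 (0.08 log units; within the scatter) as its step, which means that compound 1, compound 2 and compound 3 all lie within the scatter of one another and that none of these three groups can be ranked above another. There is no evidence here that would explain this flat result.

The compounds shown carry only a chloro or a nitro group on the phenyl ring, so it remains open whether an amine or a carboxylic acid there, or a second chlorine on the same ring, would move the number beyond the scatter. As far as these compounds go, it is also open whether the number would hold with a pyridine ring or a longer chain in place of the phenyl ring on the carbon with a double bond to nitrogen.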